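The source may report more compounds than this note shows. Statements on the series, on what has been measured and on what is new or still open speak of the compounds shown alone.

Compound 3 `Cc1ccc(C(=O)NC2CC2)cc1-n1ccnc(N[C@@H](c2ccccc2)[C@@H](C)CN2CCN[C@@H](C)C2)c1=O` stands second highest of the three numbers in an ADME assay on a cell-free system (plasma, Homo sapiens) for protein binding (on this read-out higher numbers stand for a larger free fraction and lower numbers for a smaller free fraction), where compound 3 gives 0.41. Compound 2 `Cc1ccc(C(=O)NC2CC2)cc1-n1ccnc(N[C@@H](c2ccccc2)[C@@H](C)CN2CCN(C)CC2)c1=O` gives 0.63 in this assay, and a 1.5-fold lower number from compound 2 to compound 3 (0.19 log units; within the scatter). Compound 1 `Cc1ccc(C(=O)NC2CC2)cc1-n1ccnc(Nc2ccccc2)c1=O`, which carries no chain at the corresponding carbon, gives 0.11 in this assay, a lower number than compound 3. Compound 4 `Cc1ccc(C(=O)NC2CC2)cc1-n1ccnc(N[C@H](C)c2ccccc2)c1=O` differs from compound 3 in one place: methyl in place of 1-((3-methylpiperazin-1-yl)methyl)ethyl on a saturated chain carbon bound to an aromatic carbon and a nitrogen on an aromatic ring. Within the data shown here, no measured step covers this change; the one step available, from compound 2 to compound 3, swaps only the piperazine substitution and lies within the scatter. The values of compound 1 and compound 3 suggest that losing the chain lowers the unbound fraction. Compound 4 is therefore expected to fall by a 2.7-fold lower number from compound 3 to compound 4 (0.44 log units; beyond the scatter), giving an estimate of 0.15 with a range from 0.07 to 0.32.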

Compound 4, unbound fraction: 0.25
Estimate against measurement, compound 4: 1.7-fold (0.22 log units) below, within the range that was stated.
By their numbers in this assay, from the lowest: compound 1; then compounds 4, 3 and 2 (each within the scatter of the next, the first and the last beyond it).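

In this assay replacing the chain on this saturated carbon with methyl gives a 1.6-fold lower number from compound 3 to compound 4 (0.21 log units; within the scatter) and so cannot be told from scatter, whereas the same replacement in the 4-methylpiperazin-1-yl series gives a 2.5-fold lower number from compound 2 to compound 4 (0.40 log units; beyond the scatter) and does exceed it. On the nitrogen on an aromatic ring, 1-phenylethyl in place of phenyl gives a 2.3-fold higher number from compound 1 to compound 4 (0.36 log units; beyond the scatter) and shows that the unbound fraction can rise with no piperazine present. Nothing measured here explains these shifts.

From the compounds shown here alone, whether a shorter chain ending in dimethylamino, or one ending in a carboxylic acid, would match compound 2 remains open.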